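The source may report more compounds than this note shows. Statements on the series, on what has been measured and on what is new or still open speak of the compounds shown alone.

Three related compounds have been tested in a functional assay on A549 cells (Homo sapiens) for antiproliferative activity, read by MTT assay, with a stated time of 48 h; on this read-out higher numbers stand for weaker inhibition and lower numbers for stronger inhibition. Compound 1 `COc1ccc(-c2nnc(NC(=O)/C=C/c3ccccc3)s2)cc1` gives 0.68 ug/mL. Compound 2 `O=C(/C=C/c1ccccc1)Nc1nnc(-c2ccc(Cl)cc2)s1` gives 2.02 ug/mL. Compound 3 `O=C(/C=C/c1ccccc1)Nc1nnc(-c2ccc(Br)cc2)s1` gives 2.18 ug/mL. Compound 3 sits at the high end of these numbers, yet it is not separated from compound 2, as the step of a 1.1-fold higher number from compound 2 to compound 3 (0.03 log units; within the scatter) shows; both halogen-bearing compounds stand clearly apart from compound 1, seen in a 3.0-fold higher number from compound 1 to compound 2 (0.47 log units; beyond the scatter) and a 3.2-fold higher number from compound 1 to compound 3 (0.51 log units; beyond the scatter).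

Compound 4 `O=C(/C=C/c1ccc(F)cc1)Nc1nnc(-c2ccc(Br)cc2)s1` differs from compound 3 in a single spot: fluoro in place of hydrogen on an aromatic carbon. Among the compounds with values here, no measured step touches this part of the shared core; all three concern a different ring, where a halogen replaced methoxy or one halogen replaced another. The swap of bromo for chloro, a 1.1-fold higher number from compound 2 to compound 3 (0.03 log units; within the scatter), is the nearest in kind, a small change on an aromatic ring, and it stayed within the scatter. Adding fluoro is judged a comparably small change, so the step expected in this assay, a 1.1-fold lower number from compound 3 to compound 4 (0.04 log units; within the scatter), is none beyond the scatter. Compound 4 is therefore estimated at 2 ug/mL, within 0.9 ug/mL to 4.5 ug/mL.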

Compound 4, half-maximal inhibitory concentration: 2.83 ug/mL
The estimate for compound 4 lay 1.4-fold (0.15 log units) below the measured number, within the range that was stated.
By their numbers in this assay, from the lowest: compound 1; then compounds 2, 3 and 4 (each within the scatter of the next).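

Within the data shown here, every earlier step concerned one ring of the shared core, so compound 4 gives the first reading on the other ring, where phenyl becomes 4-fluorophenyl. In this assay, this step (a 1.3-fold higher number from compound 3 to compound 4 (0.11 log units; within the scatter)) leaves compound 3 and compound 4 indistinguishable, so a fluoro on this aromatic carbon, para to a large group, is tolerated here without a detectable loss or gain. No supporting measurement accompanies this result to help interpret it.

This single pair cannot show whether an amine or a carboxylic acid at the same place would give a clearly different number. It also leaves open whether fluoro would behave the same way if the bromo of compound 4 were replaced by the methoxy found in compound 1.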